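The source may hold more compounds than are shown below. What is called first, only, known or untested is meant among the compounds shown, and "the series" means these compounds.

In an ADME assay on WI-38 cells (Homo sapiens) for cytotoxicity, read by MTT assay, with a stated time of 72 h (on this read-out higher numbers stand for weaker inhibition and lower numbers for stronger inhibition), three compounds have been measured so far:

compound 1 `CN(C)CCn1cnnc1-c1cc(Oc2ccc(NC(=O)Nc3ccc(F)c(Cl)c3)cc2F)ccn1` gives 7580 nM;
compound 2 `CN(C)CCn1cnnc1-c1cc(Oc2ccc(NC(=O)Nc3ccc(Cl)cc3Cl)cc2F)ccn1` gives 10400 nM;
compound 3 `CCN(CC)CCn1cnnc1-c1cc(Oc2ccc(NC(=O)Nc3ccc(F)c(Cl)c3)cc2F)ccn1` gives 28700 nM.

Compound 2 differs from compound 1 by 2,4-dichlorophenyl in place of 3-chloro-4-fluorophenyl on an amide-type nitrogen, a change that gave a 1.4-fold higher number from compound 1 to compound 2 (0.14 log units; within the scatter). Compound 3 differs from compound 1 by diethylamino in place of dimethylamino on a saturated chain carbon, two bonds along the chain from an aromatic nitrogen, which gave a 3.8-fold higher number from compound 1 to compound 3 (0.58 log units; beyond the scatter), and compound 3 stands as the highest number of the three.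

Compound 4 `CCN(CC)CCn1cnnc1-c1cc(Oc2ccc(NC(=O)Nc3ccc(Cl)cc3Cl)cc2F)ccn1` has not yet been measured. It differs from compound 3 by 2,4-dichlorophenyl in place of 3-chloro-4-fluorophenyl on an amide-type nitrogen, the same change already seen between compound 1 and compound 2, now made on the core of compound 3. The step from compound 3 to compound 4 in this assay is expected to be small, a 1.3-fold higher number from compound 3 to compound 4 (0.12 log units; within the scatter), because this change earlier gave a 1.4-fold higher number from compound 1 to compound 2 (0.14 log units; within the scatter). Compound 4 is therefore estimated at 38000 nM, expected to fall between 17000 nM and 85000 nM.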

Compound 4, half-maximal inhibitory concentration: 4280 nM
Beside the measured number, compound 4's estimate is 8.9-fold (0.95 log units) above it; measured number below the stated range.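

In this assay, 2,4-dichlorophenyl in place of 3-chloro-4-fluorophenyl gives a 6.7-fold lower number from compound 3 to compound 4 (0.83 log units; beyond the scatter), so this change did not carry over from the core of compound 1 to the core of compound 3: the same change on two cores in this assay, a 1.4-fold higher number (0.14 log units; within the scatter) from compound 1 to compound 2 and a 6.7-fold lower number (0.83 log units; beyond the scatter) from compound 3 to compound 4, 9.2-fold (0.96 log units) apart, beyond the scatter of two such steps

Diethylamino in place of dimethylamino likewise gives a 2.4-fold lower number from compound 2 to compound 4 (0.39 log units; beyond the scatter), so its step also depends on the group on the amide-type nitrogen: the same change on two cores in this assay, a 3.8-fold higher number (0.58 log units; beyond the scatter) from compound 1 to compound 3 and a 2.4-fold lower number (0.39 log units; beyond the scatter) from compound 2 to compound 4, 9.2-fold (0.96 log units) apart, beyond the scatter of two such steps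

These four compounds show that the two changes do not act independently here, but they do not show why, and a single pair of steps for each change gives no general rule for the series.

As far as these compounds go, it remains open whether another amine on the chain, such as pyrrolidine or morpholine, would follow diethylamino or dimethylamino. The same question applies to a longer chain and to another aryl group, such as 4-chlorophenyl.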